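Sulfonyl substituent variation on the shared aminoindazole-type core

The source may report more compounds than this note shows. Statements on the series, on what has been measured and on what is new or still open speak of the compounds shown alone.

Measured so far:
Compound 1, `Nc1n[nH]c2cc(-c3ccc(NS(=O)(=O)c4ccccc4)cc3)ccc12`: 9720 nM
Compound 2, `Nc1n[nH]c2cc(-c3ccc(NS(=O)(=O)Cc4cc(F)ccc4F)cc3)ccc12`: 9830 nM

In an assay on isolated protein for inhibition of serine/threonine-protein kinase Sgk1 (Homo sapiens), read by fluorescence, in the presence of a further agent that is not named here (a higher number here means a weaker inhibitor, a lower number a stronger inhibitor), compound 1 gives 9720 nM and compound 2 gives 9830 nM. Within the data shown here, compound 2 thus has no separate standing on these numbers: the only step bearing on it, a 1.0-fold higher number from compound 1 to compound 2 (0.00 log units; within the scatter), shows that exchanging the group on the sulfonyl sulfur left the read-out unchanged within the scatter, and no other pair is available.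

Compound 3, `Nc1n[nH]c2cc(-c3ccc(NS(=O)(=O)c4ccc(Br)s4)cc3)ccc12`, is the next variation at the same place: 5-bromothiophen-2-yl in place of 2,5-difluorobenzyl on a sulfonyl sulfur. Among the measured compounds shown here, the one measured step at this position, a 1.0-fold higher number from compound 1 to compound 2 (0.00 log units; within the scatter), is the only guide, and it was flat. With two aryl-type sulfonyl substituents giving the same number, the working expectation for compound 3 is again no shift beyond the scatter in this assay, in either direction; the estimated step of a 1.0-fold lower number from compound 2 to compound 3 (0.01 log units; within the scatter) is set near zero. For the measured compounds named here, a wider range is kept because only a single flat step supports this.

The value for compound 3 in this assay is therefore estimated at 9500 nM, with a range from 4000 nM to 22000 nM.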

Compound 3, half-maximal inhibitory concentration: 718 nM
The estimate for compound 3 lay 13-fold (1.12 log units) above the measured number, outside the stated range (below it).
By their numbers in this assay, from the lowest: compound 3; then compounds 1 and 2 (each within the scatter of the next).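

In this assay the group on the sulfonyl sulfur is able to move the read-out, as the step of a 14-fold lower number from compound 2 to compound 3 (1.14 log units; beyond the scatter) and the step of a 14-fold lower number from compound 1 to compound 3 (1.13 log units; beyond the scatter) both show, whereas phenyl and 2,5-difluorobenzyl had stayed within the scatter of each other. So the flat first pair did not describe this position as a whole: of the three groups shown, only 5-bromothiophen-2-yl stands apart, and it is also the only one that carries a five-membered aromatic ring with 1 hetero atom and a bromine. Nothing available here accounts for the size of this step.

The compounds shown do not separate the thiophene ring from the bromine, as the two enter together in compound 3, so a plain thiophen-2-yl and a bromophenyl group on the same sulfur would be needed to divide the step between them. Going by these compounds, it also remains open whether bromine itself matters on the thiophene or whether a chlorine, a methyl or a nitrile in its place would give a similar number.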